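Sulfonamide in Place of Butyl on a Triazole Side Chain

A few compounds are considered here, and "the series" means these few. Any claim that something is new, unique, unknown or untested is made for them only; others in the source may bear on it.

Compound 1: `O=C1O/C(=C\Cn2cc(-c3ccc(Br)cc3)nn2)C(OCc2ccccc2)=C1OCc1ccccc1` – > 100000 nM
Compound 2: `O=C1O[C@H]([C@@H](O)Cn2cc(-c3cc(C(F)(F)F)cc(C(F)(F)F)c3)nn2)C(OCc2ccccc2)=C1OCc1ccccc1` – 66500 nM
Compound 3: `CCCCc1cn(C[C@H](O)[C@H]2OC(=O)C(OCc3ccccc3)=C2OCc2ccccc2)nn1` – 73200 nM

Of the compounds shown here, three sharing the same dibenzyloxy core have been tested in a functional assay on CFPAC-1 cells (Homo sapiens) for antiproliferative activity, read by MTT assay, with a stated time of 72 h; a lower number here means a stronger inhibitor, a higher number a weaker inhibitor. For compound 1 the result of > 100000 nM is a limit of the assay, not a number (the limit of > 100000 nM in this assay, at which 1 of the 3 values shown sits). Compound 2 gives 66500 nM. Compound 3 gives 73200 nM, the higher of the two numbers, but its gap to compound 2 lies within the scatter of this assay, so the two cannot be ordered.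

Compound 4, `O=C1O[C@H]([C@@H](O)Cn2cc(CNS(=O)(=O)c3ccc(Cl)cc3)nn2)C(OCc2ccccc2)=C1OCc1ccccc1`, has not yet been measured in this assay. It differs from compound 3 by ((4-chlorophenyl)sulfonyl)amino in place of propyl on a saturated chain carbon bound to an aromatic carbon; in words, ((4-chlorophenyl)sulfonyl)amino in place of propyl on a saturated chain carbon bound to an aromatic carbon. Within the data shown here, no measured pair in this set isolates such a change, so there is no direct precedent for its size or direction. Given that both numbered values, for compound 2 with 66500 nM and compound 3 with 73200 nM, sit close together despite different triazole substituents, compound 4 is expected to land in a similar region, with a step of a 1.3-fold lower number from compound 3 to compound 4 (0.12 log units; within the scatter) that would not exceed the scatter. The estimate for compound 4 in this assay is 55000 nM, between 18000 nM and 150000 nM.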

Compound 4, half-maximal inhibitory concentration: 38900 nM
Estimate against measurement, compound 4: 1.4-fold (0.15 log units) above; the range from low to high includes it.
By their numbers in this assay, from the lowest: compounds 4, 2 and 3 (each within the scatter of the next). At a limit, above all of these: compound 1.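

In this assay, putting ((4-chlorophenyl)sulfonyl)amino in place of propyl on a saturated chain carbon bound to an aromatic carbon gives a 1.9-fold lower number from compound 3 to compound 4 (0.27 log units; within the scatter), so this change cannot be told apart from no effect. Among these compounds, this is the only pair in the set that differs in one place, and it gives the first direct reading at this position: the entering group brings a six-membered aromatic ring, a hydrogen-bond donor and two hydrogen-bond acceptors, none of which the propyl it replaces has, yet the step stays within the scatter. Nothing measured here bears on why so large a change in the group leaves the reading within the scatter.

Going by these compounds, it remains open whether any other group at this place, such as an amine, a carboxylic acid or a longer chain, would give a step beyond the scatter in this assay. Also open, on these data alone, is whether the chlorine on the phenyl ring or the sulfonyl link contributes anything separately, since the two enter together in this single pair.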